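The compounds below may be only part of what the source reports. "The series", "measured", "known", "first", "only" and "open" are said of these compounds alone.

Measured compounds:
Compound 1, `Cc1ccc(C(=O)Nc2cccc(C(F)(F)F)c2)cc1-c1ccc2c(-c3cnn(C)c3)n[nH]c2c1`: in an assay on isolated protein for inhibition of Discoidin domain-containing receptor 2 (Homo sapiens), read by ELISA, with a stated time of 60 min (a lower number here means a stronger inhibitor, a higher number a weaker inhibitor), compound 1 gives 4.4 nM.
Compound 2, `Cc1ccc(C(=O)Nc2cccc(C(F)(F)F)c2)cc1-c1ccc2c(-c3cnn(C4CC4)c3)n[nH]c2c1`: in this assay compound 2 gives 3.2 nM.
Compound 3, `Cc1ccc(C(=O)Nc2cccc(C(F)(F)F)c2)cc1-c1ccc2c(-c3cnn(C4CCOC4)c3)n[nH]c2c1`: in this assay compound 3 gives 6.2 nM.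

All three share one core and differ only in the group on an aromatic nitrogen of the five-membered aromatic ring with two nitrogens. Compound 3 has the highest of the three numbers, yet its gaps to the others are small: a 1.4-fold higher number from compound 1 to compound 3 (0.15 log units; within the scatter) and a 1.9-fold higher number from compound 2 to compound 3 (0.29 log units; within the scatter), both within the scatter, as is a 1.4-fold lower number from compound 1 to compound 2 (0.14 log units; within the scatter). So far, swapping this group has produced no step that can be trusted.

Compound 4, `Cc1ccc(C(=O)Nc2cccc(C(F)(F)F)c2)cc1-c1ccc2c(-c3cnn(C4CCN(C)CC4)c3)n[nH]c2c1`, carries the next swap at the same place: 1-methylpiperidin-4-yl in place of oxolan-3-yl on an aromatic nitrogen. Within the data shown here, the three measured steps all bear on it, since each changes only this group, and each was within the scatter. The new group is larger than any tried so far, so the outcome is less certain, but the evidence supports no step beyond the scatter in this assay in either direction. Compound 4 is therefore expected to give about 6 nM, with a range from 2.5 nM to 15 nM, which would mean an expected step of a 1.0-fold lower number from compound 3 to compound 4 (0.01 log units; within the scatter).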

Compound 4, half-maximal inhibitory concentration: 3.8 nM
The estimate for compound 4 lay 1.6-fold (0.20 log units) above the measured number; low and high end bracket the measured number.
By their numbers in this assay, from the lowest: compounds 2, 4, 1 and 3 (each within the scatter of the next).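

Moving to the larger 1-methylpiperidin-4-yl group, with 7 heavy atoms and a ring nitrogen where oxolan-3-yl has 5 and a ring oxygen, still gives no step that can be trusted in this assay: a 1.6-fold lower number from compound 3 to compound 4 (0.21 log units; within the scatter) and a 1.2-fold higher number from compound 2 to compound 4 (0.07 log units; within the scatter) and a 1.2-fold lower number from compound 1 to compound 4 (0.06 log units; within the scatter) all lie within the scatter. The aromatic nitrogen of the five-membered ring therefore accepts a six-membered non-aromatic ring as well as the three smaller groups, and the four compounds cannot be told apart here. No supporting measurement is available to explain this flatness.

From the compounds shown here alone, whether a carboxylic acid, or a longer chain ending in an amine, at this nitrogen would produce a step beyond the scatter remains open. Also open, going by these compounds, is how these four compounds compare in any test other than this assay.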